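Bromo-naphthyridine amides: ester versus anilide

The source may hold more compounds than are shown below. What is called first, only, known or untested is meant among the compounds shown, and "the series" means these compounds.

Measured so far:
- compound 1 `COc1ccc(CNC(=O)c2nc(Br)c3cccnc3c2N[C@H]2CC[C@H](N)CC2)cc1` — 5000 nM in a functional assay on SK-BR-3 cells (Homo sapiens) for cytotoxicity, read by MTT assay, with a stated time of 72 h; on this read-out lower numbers stand for stronger inhibition and higher numbers for weaker inhibition
- compound 2 `COC(=O)c1nc(Br)c2cccnc2c1N[C@H]1CC[C@H](N)CC1` — "not determined" (no result reported)

Compound 2 stands without a number: in this assay compound 2 gives "not determined" (no result reported), so no value of its own anchors the step. The only measured point in the series is compound 1, which in this assay gives 5000 nM; its amide is built on the same core as compound 2 and compound 3, and that value is the only reference for what an amide at this position does.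

Compound 3 `N[C@H]1CC[C@H](Nc2c(C(=O)Nc3ccccc3)nc(Br)c3cccnc23)CC1` is to be measured in this assay. It differs from compound 2 by anilino in place of methoxy on a carbonyl carbon — anilino in place of methoxy on a carbonyl carbon.

Within the data shown here, no step between measured compounds exists, so no size for this change can be read from the data. In this assay the expectation is a step of undetermined size, with no preferred direction, because the ester of compound 2 has no number and compound 1 gives 5000 nM as the only related amide. Compound 3 is expected near 5000 nM, within 1500 nM to 15000 nM.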

Compound 3, half-maximal inhibitory concentration: 2000 nM
Estimate against measurement, compound 3: 2.5-fold (0.40 log units) above; the range from low to high includes it.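

In this assay, the amide at this carbonyl now has its first measured step: phenyl in place of 4-methoxybenzyl on the amide-type nitrogen gives a 2.5-fold lower number from compound 1 to compound 3 (0.40 log units; beyond the scatter), modest in size but beyond the scatter. The group on this nitrogen therefore registers on the read-out, and of the two amides shown, compound 3 carries the lower number, 2000 nM. The step from compound 2 to compound 3 cannot be read, with no number for compound 2, so ester against amide stays unsettled, and no measurement at hand accounts for the lower number of the phenyl amide.

The step from compound 1 to compound 3 changes the methylene link and the ring methoxy together, so the compounds shown do not say which of the two carries it; a benzyl amide without the methoxy and a 4-methoxyphenyl amide would separate them. Also open, from the compounds shown here alone, is how this carbonyl behaves with a carboxylic acid or a simple methyl amide in place of the aromatic amides.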